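The compounds below may be only part of what the source reports. "The series", "measured", "known", "first", "only" and "open" are said of these compounds alone.

Measured compounds:
compound 1, `Brc1cccc(/N=N/N2CCCCC2)c1`, 85000 nM
compound 2, `O=[N+]([O-])c1cccc(/N=N/N2CCCCC2)c1`, 83000 nM
compound 3, `Clc1cccc(/N=N/N2CCCCC2)c1`, > 100000 nM

Three compounds of this series have been examined in an ADME assay on Vero cells (Chlorocebus sabaeus) for cytotoxicity, read by crystal violet staining; a lower number here means that less compound is tolerated, a higher number that more compound is tolerated. For compound 3 the number given is a limit of the assay and not a measured number, so all that is known of where compound 3 stands is that it sits at the limit of > 100000 nM in this assay, at which 1 of the 3 values shown sits. Between the two compounds with real numbers the step is a 1.0-fold lower number from compound 1 to compound 2 (0.01 log units; within the scatter). The two steps that end at the limit, an at least 1.1-fold higher number from compound 1 to compound 3 (0.07 log units; that floor lies within the scatter) and an at least 1.2-fold higher number from compound 2 to compound 3 (0.08 log units; that floor lies within the scatter), have floors that lie within the scatter as well.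

For the measured compounds named here, the next compound, compound 4, is `c1ccc(/N=N/N2CCCCC2)cc1`. hydrogen in place of chloro on an aromatic carbon No measured step removes a substituent entirely; the closest comparisons are the swaps of chloro in place of bromo and chloro in place of nitro on an aromatic carbon, neither of which moved the number beyond the scatter. A step of no more than the scatter is therefore expected in this assay from compound 3 to compound 4, and compound 4 may again reach the limit. Compound 4 is expected near 100000 nM, within 40000 nM to 250000 nM. That estimate means an expected step of a number no higher from compound 3 to compound 4 (the limit leaves the size open).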

Compound 4, half-maximal cytotoxic concentration: > 100000 nM
Compound 4: only a limit was reported (the forecaster's own chance of this, stated with the estimate: 45%); the middle value sits exactly at the limit.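

For the compounds shown here, replacing chloro with hydrogen on this aromatic carbon adds something the earlier compounds could not show: the bare ring carbon, with no substituent at all, also reaches the ceiling of this assay: the limit of > 100000 nM in this assay, at which 2 of the 4 values shown sit. Compound 3 and compound 4 both stand at a limit, so the step between them cannot be read, and nothing can be said about whether chloro and hydrogen differ here. Against the two compounds with real numbers, the record gives an at least 1.2-fold higher number from compound 2 to compound 4 (0.08 log units; that floor lies within the scatter) and an at least 1.1-fold higher number from compound 1 to compound 4 (0.07 log units; that floor lies within the scatter), so neither floor sets the hydrogen compound apart from the nitro or bromo compound, and the true size of both steps remains unknown.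

Across hydrogen, chloro, bromo and nitro on this carbon, no step is printed as beyond the scatter, and the limits hide any difference among the compounds that reach them. From the compounds shown here alone, whether an amine or a carboxylic acid on this aromatic carbon would move the number beyond the scatter remains open, as does the effect of a change elsewhere in the shared core.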